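This account rests on a few compounds, and the source may have more. Where it says the series, first, only, none or still open, it means among the compounds named here.

Compound 1, `CC(C)n1ncc2c(C(=O)NCc3cn(-c4ccccc4)nn3)cccc21`, was tested in a functional assay on HepG2 cells (Homo sapiens) for inhibition, read by MTT assay, with a stated time of 72 h; on this read-out lower numbers stand for stronger inhibition and higher numbers for weaker inhibition. In this assay compound 1 gives only a limit, > 40000 nM, and not a measured number. Two close relatives were measured in the same way. Compound 2, `CC(C)n1ncc2c(C(=O)NCc3cn(-c4ccccc4F)nn3)cccc21`, also returns a limit, > 40000 nM. Compound 3, `CC(C)n1ncc2c(C(=O)NCc3cn(-c4ccc(C(F)(F)F)cc4)nn3)cccc21`, likewise returns a limit, > 40000 nM. Because all three values sit at the limit of > 40000 nM in this assay, at which 3 of the 3 values shown sit, the steps among them cannot be read: a step that the two limits leave unreadable from compound 1 to compound 2, a step that the two limits leave unreadable from compound 1 to compound 3 and a step that the two limits leave unreadable from compound 2 to compound 3 each stay hidden by the limit. Compound 4, `COc1ccc(Cn2cc(CNC(=O)c3cccc4c3cnn4C(C)C)nn2)cc1`, has not yet been measured. It differs from compound 1 by a single change: 4-methoxybenzyl in place of phenyl on an aromatic nitrogen. Going by the values given here, none of the measured steps alters this part of the molecule in this way, and all of them are unreadable, so the measured compounds give no guide to the size or direction of the change. The step expected from compound 1 to compound 4 is therefore a number no higher from compound 1 to compound 4 (the limit leaves the size open), with no clear direction. Compound 4 is estimated at 40000 nM, in a range from 15000 nM to 100000 nM, because compound 1 itself gives only the limit > 40000 nM and this assay may again report only a limit.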

Compound 4, half-maximal inhibitory concentration: > 40000 nM
Compound 4: no number, only a limit (the forecaster's own chance of this, stated with the estimate: 75%); the middle value lies on the limit itself.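

In this assay, going by these compounds alone, compound 4 gives only a limit (> 40000 nM), so no step from compound 1, compound 2 or compound 3 to compound 4 can be read, and all four share one limit: the limit of > 40000 nM in this assay, at which 4 of the 4 values shown sit. The compounds shown leave open whether any change on this aromatic nitrogen affects inhibition.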